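A few compounds are considered here, and "the series" means these few. Any claim that something is new, unique, unknown or untested is made for them only; others in the source may bear on it.

Of the compounds shown here, three of a shared core have been tested in a functional assay on the whole organism (Tail, strain ICR) with Mus musculus as the target, in the tail flick test, with a stated time of 30 min, at a dose of 25 umol/kg by the oral route; a lower number here means a weaker effect, a higher number a stronger effect of the compound at the dose given. Compound 1, `NC(=O)CC[C@H](NC(=O)CN(c1ncnc2c1ncn2C1CCCCO1)C1CC1)C(=O)OCc1ccccc1`, gives 47%. Compound 2, `O=C(CN(c1ncnc2c1ncn2C1CCCCO1)C1CC1)NCC(=O)OCc1ccccc1`, gives 55.7%. Compound 3, `NC(=O)C[C@H](NC(=O)CN(c1ncnc2c1ncn2C1CCCCO1)C1CC1)C(=O)OCc1ccccc1`, gives 34.5%, the lowest of the three numbers. Between compound 1 and compound 2 the step is a number 8.7 percentage points higher from compound 1 to compound 2 (within the scatter), so these two values cannot be ranked against each other. The step of a number 12.5 percentage points lower from compound 1 to compound 3 (beyond the scatter) and the step of a number 21.2 percentage points lower from compound 2 to compound 3 (beyond the scatter) both exceed the scatter and both end at compound 3.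

Compound 4, `O=C(CN(c1ncnc2c1ncn2C1CCCCO1)C1CC1)N[C@@H](CC(=O)OCc1ccccc1)C(=O)OCc1ccccc1`, has not been measured. Compared with compound 3 it shows (benzyloxy in place of amino on a carbonyl carbon). Among the measured compounds shown here, none of the three measured steps changes this part of the molecule; the earlier steps all alter the carbon chain that carries the carbamoyl group, not the carbonyl carbon itself. For the measured compounds named here, there is therefore no measured step that bears directly on the exchange of amino for benzyloxy, and any expectation rests only on the values in hand. With compound 3 as the starting point, the step from compound 3 to compound 4 in this assay is expected to be a number 5.5 percentage points higher from compound 3 to compound 4 (within the scatter), but the range around it is wide. Compound 4 is estimated to give 40%, with a range from 20% to 60%.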

Compound 4, a percentage reported as activity, at one dose (the size of the read-out at that dose, not a potency): 31.8%
For compound 4 the middle estimate is 8.2 percentage points above the measured one, and the stated range covers the measured number.
By their numbers in this assay, from the lowest: compounds 4 and 3 (each within the scatter of the next); then compounds 1 and 2 (each within the scatter of the next).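

In this assay, benzyloxy in place of amino on the carbonyl carbon brings in a six-membered aromatic ring and removes a hydrogen-bond donor, yet the values of the two compounds cannot be told apart (a number 2.7 percentage points lower from compound 3 to compound 4 (within the scatter)), so this large exchange at the end of the side chain has no readable effect at the dose given. The ester-ended side chain also stays apart from the other two compounds, with (benzyloxycarbonyl)methyl in place of hydrogen giving a number 23.9 percentage points lower from compound 2 to compound 4 (beyond the scatter) and benzyloxycarbonyl in place of carbamoylmethyl giving a number 15.2 percentage points lower from compound 1 to compound 4 (beyond the scatter), which places compound 4 with compound 3 on the low side of both compound 1 and compound 2. Nothing in the data explains why the amino and benzyloxy ends read alike.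

Still open, as far as these compounds go, is whether a carboxylic acid or a small methoxy on the same carbonyl carbon would also stay level with compound 3. From the compounds shown here alone, it is equally open whether benzyloxy on the longer chain of compound 1, giving a 2-(benzyloxycarbonyl)ethyl group, would match compound 1 as closely as compound 4 matches compound 3.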